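Tert-butyl to isopropyl on the phenyl ester of a pyrazole amide

This account rests on a few compounds, and the source may have more. Where it says the series, first, only, none or still open, it means among the compounds named here.

Three compounds share one core. Compound 1 `Cc1ccc(-c2cc(C(=O)NCc3cccnc3)n(Cc3ccccc3)n2)cc1` gives 24.4% in a functional assay on the whole organism (strain Swiss albino) for inhibition, with Mus musculus as the target, read by paw edema, with stated times of 30 min and 270 min, at a dose of 100 mg/kg by the subcutaneous route; a higher number here means more inhibition at the dose given (going by the name of the read-out), a lower number less inhibition. Among the measured compounds shown here, compound 2 `Cc1ccc(-c2cc(C(=O)NNc3ccc4ccccc4n3)n(Cc3ccccc3)n2)cc1` gives 44.4%, and the single one-place step on record, a number 20 percentage points higher from compound 1 to compound 2 (beyond the scatter), concerns the amide-type nitrogen. Compound 3 `Cc1ccc(-c2cc(C(=O)Oc3ccc(C(C)(C)C)cc3)n(Cc3ccccc3)n2)cc1` gives 50%, which lies beyond the scatter above compound 1 and within the scatter of compound 2. Compound 4 `Cc1ccc(-c2cc(C(=O)Oc3ccc(C(C)C)cc3)n(Cc3ccccc3)n2)cc1` differs from compound 3 by hydrogen in place of methyl on a saturated chain carbon bound to an aromatic carbon and two saturated chain carbons. For the measured compounds named here, no measured step touches the ester side of the core, so nothing on record bears directly on this change. The loss of a single carbon is therefore expected to leave the read-out unchanged beyond the scatter, an expected step of a number 3 percentage points lower from compound 3 to compound 4 (within the scatter). Compound 4 is estimated at 47%, between 34% and 60%.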

Compound 4, a percentage reported as inhibition, in the whole organism at one dose (the size of the read-out at that dose, not a potency): 29%
Compound 4: middle estimate off by 18 percentage points, on the high side, outside the stated range (below it).
By their numbers in this assay, from the lowest: compounds 1 and 4 (each within the scatter of the next); then compounds 2 and 3 (each within the scatter of the next).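

On the ester side of the core, the loss of one methyl in going from tert-butyl to isopropyl gives a number 21 percentage points lower from compound 3 to compound 4 (beyond the scatter), so this group's read-out depends on that single carbon. The step of 4-isopropylphenoxy in place of ((pyridin-3-yl)methyl)amino is a number 4.6 percentage points higher from compound 1 to compound 4 (within the scatter), so the ester linkage alone does not secure the number seen for compound 3. No evidence on record explains this difference.

Open, as far as these compounds go, is whether ethyl, cyclopropyl or trifluoromethyl in place of the tert-butyl would read like tert-butyl or like isopropyl. Also open, from the compounds shown here alone, is whether a tert-butyl group on the amide side would matter as it does on the ester.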